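Replacing the Bromo Group on a Ketone-Bearing Heterocycle

The source may report more compounds than this note shows. Statements on the series, on what has been measured and on what is new or still open speak of the compounds shown alone.

Among the measured compounds shown here, compound 1 `O=C(CCCCCCc1ccccc1)c1nc(Br)co1` stands as the stronger of the two compounds measured so far in an assay on isolated protein for inhibition of Fatty-acid amide hydrolase 1 (Rattus norvegicus) (a lower number here means a stronger inhibitor, a higher number a weaker inhibitor), where compound 1 gives 3 nM. For the measured compounds named here, its only measured neighbour, compound 2 `CSc1coc(C(=O)CCCCCCc2ccccc2)n1`, differs by a methylsulfanyl in place of bromo on an aromatic carbon, and in this assay compound 2 gives 29 nM. Going by the values given here, that single step, a 9.7-fold higher number from compound 1 to compound 2 (0.99 log units; beyond the scatter), is the only change at this site seen so far. Compound 3 `O=C(CCCCCCc1ccccc1)c1nc(C(=O)C(F)(F)F)co1` alters the same aromatic carbon of compound 1: (trifluoromethyl)carbonyl in place of bromo on an aromatic carbon. The step from compound 1 to compound 2 bears on this change, and it was modest and upward. Among the compounds with values here, the entering group here is larger and of a different kind, so no measured pair fixes the size of the new step; a step of comparable size is expected, more likely upward than downward. Compound 3 is therefore estimated at 8 nM, within 1.5 nM to 60 nM, which would mean a 2.7-fold higher number from compound 1 to compound 3 (0.43 log units; beyond the scatter).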

Compound 3, inhibition constant: 470 nM
The estimate for compound 3 lay 59-fold (1.77 log units) below the measured number; measured number above the stated range.
By their numbers in this assay, from the lowest: compound 1; then compound 2; then compound 3.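

In this assay, (trifluoromethyl)carbonyl in place of bromo gives a 160-fold higher number from compound 1 to compound 3 (2.19 log units; beyond the scatter), showing that this aromatic carbon, next to the ring nitrogen, can respond to its substituent far more strongly than the first pair revealed. The same group in place of methylsulfanyl gives a 16-fold higher number from compound 2 to compound 3 (1.21 log units; beyond the scatter), so the two replacements of bromo differ widely, and bromo keeps the lowest number of the three. Nothing available bears on the reason for these steps.

The three compounds leave open whether the number follows the size of the entering group or its kind. Hydrogen, chloro, methyl, a nitrile, an amine or a carboxylic acid on this carbon would show whether any group can match bromo here.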